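The source may report more compounds than this note shows. Statements on the series, on what has been measured and on what is new or still open speak of the compounds shown alone.

Compound 1 `COC(=O)c1c(-c2ccc([N+](=O)[O-])cc2)oc2ccccc2c1=O` and compound 2 `COC(=O)c1c(-c2ccc([N+](=O)[O-])cc2)oc2cc(OC)ccc2c1=O` share one core. In a functional assay on Malme-3M cells (Homo sapiens) for cytotoxicity, read by MTT assay, with a stated time of 6 days (a higher number here means that more compound is needed for the effect, a lower number that less compound is needed), compound 2 gives 1.12 ug/mL. Compound 1 reaches only the limit of this assay at > 25 ug/mL. The step of an at least 22-fold higher number from compound 2 to compound 1 (1.34 log units; beyond the scatter) is therefore only a bound because of the limit of > 25 ug/mL in this assay, at which 2 of the 3 values shown sit; the change is hydrogen in place of methoxy on an aromatic carbon. Compound 3 `COc1cc(-c2oc3ccccc3c(=O)c2C(=O)O)cc(OC)c1OC` has another core, and how the two cores differ is not broken down here. In this assay compound 3 also reaches only the limit at > 25 ug/mL. Compound 4 `COc1cc(OC)cc(-c2oc3ccccc3c(=O)c2C(=O)O)c1` differs from compound 3 by hydrogen in place of methoxy on an aromatic carbon, the same kind of change as seen earlier, though here the place is ortho to two methoxy groups and para to a large group, not meta and para to a fused ring. Since compound 3 already sits at > 25 ug/mL and the step of an at least 22-fold higher number from compound 2 to compound 1 (1.34 log units; beyond the scatter) moved toward a higher number, compound 4 is expected to stay at the limit, the expected step being a step that the limit leaves unreadable from compound 3 to compound 4. Compound 4 is estimated at 35 ug/mL.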

Compound 4, concentration for half-maximal effect: > 25 ug/mL
Compound 4 was reported as a limit; the forecaster's own chance of this, stated with the estimate: 85%; the middle value does not contradict the limit.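

Among these compounds, compound 3 and compound 4 both stand at a limit, so no step between them can be read: the limit of > 25 ug/mL in this assay, at which 3 of the 4 values shown sit. The compounds shown leave open whether hydrogen in place of methoxy changes the response of compound 3 in this assay at all.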